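This account rests on a few compounds, and the source may have more. Where it says the series, first, only, none or still open, it means among the compounds named here.

Measured compounds:
compound 1 `CCn1c(SCC(=O)c2ccccc2)nnc1-c1cc(OC)c(OC)c(OC)c1` — 41%
compound 2 `C=CCn1c(SCC(=O)c2ccccc2)nnc1-c1cc(OC)c(OC)c(OC)c1` — 62%

The read-out is a functional assay on the whole organism (strain albino) for inhibition, with Rattus norvegicus as the target, read by paw edema, with a stated time of 2 h, at a dose of 0.28 mmol/kg by the oral route; a lower number here means less inhibition, a higher number more inhibition at the dose given (going by the name of the read-out). Of the two numbers, compound 2 stands highest in this assay, and the nearest is compound 1, whose number is lower by the step of a number 21 percentage points higher from compound 1 to compound 2 (beyond the scatter), which lies beyond the scatter.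

Compound 3 `COc1cc(-c2nnc(SCC(=O)c3ccccc3)n2-c2ccccc2)cc(OC)c1OC` is not yet measured. It differs from compound 2 by phenyl in place of allyl on an aromatic nitrogen. For the measured compounds named here, the only measured step, from compound 1 to compound 2, concerns the same position but a different kind of change, vinyl in place of methyl on a saturated chain carbon bound to an aromatic nitrogen, and it gave a modest rise. Going by the values given here, no measured pair shows a phenyl replacing an allyl, so that step bears on compound 3 only loosely: it shows only that a change at this position went with a modest shift of the number, and a change of another kind could move the number either way. The expected step for compound 3 is therefore a number 10 percentage points lower from compound 2 to compound 3 (within the scatter), a number not clearly beyond the scatter, with a wide range.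

For compound 3, the estimated value in this assay is 52%, expected to fall between 30% and 72%.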

Compound 3, a percentage reported as inhibition, in the whole organism at one dose (the size of the read-out at that dose, not a potency): 51%
Beside the measured number, compound 3's estimate is 1 percentage points above it, and the stated range covers the measured number.
By their numbers in this assay, from the lowest: compounds 1 and 3 (each within the scatter of the next); then compound 2.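

In this assay, phenyl on this aromatic nitrogen keeps a clear part of the inhibition, but it gives a number 11 percentage points lower from compound 2 to compound 3 (beyond the scatter), so compound 2 with its allyl stands above both other compounds, with each step to it printed as beyond the scatter. Phenyl in place of ethyl gives a number 10 percentage points higher from compound 1 to compound 3 (within the scatter), so these two groups are not separated despite the aromatic ring that phenyl brings; among the three groups, only allyl stands apart, and it alone has a double bond outside aromatic rings, though three compounds cannot tie the higher number to that double bond. No supporting data on these compounds account for the order of the three numbers.

Still open, as far as these compounds go, is whether a saturated propyl chain on this nitrogen would stand with allyl or with ethyl, which would separate the effect of the double bond from that of chain length, and whether a benzyl group would differ from phenyl. Each number also comes from a single oral dose and time point, so these steps give the size of the read-out at that dose and say nothing of potency.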